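The source may hold more compounds than are shown below. What is called first, only, known or untested is meant among the compounds shown, and "the series" means these compounds.

Measured so far:
- Compound 1 `NC(=O)C1CCN(c2ncc(C(=O)Nc3nc(-c4cccc(C(F)(F)F)c4F)cs3)cc2Cl)CC1`: < 10 ug/mL
- Compound 2 `O=C(Nc1nc(-c2cccc(C(F)(F)F)c2F)cs1)c1cnc(N2CCCC(C(=O)O)C2)c(Cl)c1`: < 10 ug/mL

In a physicochemical assay for solubility (a higher number here means a more soluble compound, a lower number a less soluble compound), compound 2 gives < 10 ug/mL, which is a limit of the assay and not a number. Compound 1 gives < 10 ug/mL, and this too is a limit. So the true position of compound 2 is not known, and neither compound offers a firm number to start from.

The next compound is compound 3 `O=C(Nc1nc(-c2cccc(C(F)(F)F)c2F)cs1)c1cnc(N2CCCCC2)c(Cl)c1`, which has hydrogen in place of carboxy on a saturated ring carbon. The same change can be read as 3-carboxypiperidin-1-yl to piperidin-1-yl.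

Within the data shown here, only one measured step exists, a step that the two limits leave unreadable from compound 1 to compound 2. It has no readable size, so it gives no direction for the new step. The one thing the data do show is the limit of < 10 ug/mL in this assay, at which 2 of the 2 values shown sit. With nothing measured above that limit, the expectation is that compound 3 stays in the same low region and that the assay again reports only a limit.

For compound 3 the estimated value is 4 ug/mL, with an expected range from 1 ug/mL to 12 ug/mL. The expected change is a step that the limit leaves unreadable from compound 2 to compound 3.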

Compound 3, solubility: < 10 ug/mL
Compound 3 gave a limit, no number (the forecaster's own chance of this, stated with the estimate: 90%); the middle value is on the limit's open side.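

In this assay compound 3 gives < 10 ug/mL, which is a limit of the assay and not a number. The steps to compound 3 from compound 1 and from compound 2 therefore cannot be read, and all three compounds share one limit: the limit of < 10 ug/mL in this assay, at which 3 of the 3 values shown sit. From the compounds shown here alone, how far compound 1, compound 2 and compound 3 truly differ in this assay remains open.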